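Methoxy in Place of Methyl on the Outer Ring

The compounds below may be only part of what the source reports. "The series", "measured", "known", "first", "only" and "open" are said of these compounds alone.

Compound 3 `Cc1cccc(NC(=O)C2(C(=O)Nc3ccc(Nc4ncc5cc(C(=O)N(C)C)n(C6CCCC6)c5n4)cc3)CC2)c1` gives 95.3% in a functional assay on T47D cells (Homo sapiens) for inhibition, read by CCK-8 assay, with a stated time of 72 h, tested at 10 uM (a higher number here means more inhibition of growth at the concentration tested, a lower number less inhibition of growth), and stands second highest of the three numbers shown. Compound 1 `CN(C)C(=O)c1cc2cnc(Nc3ccc(NC(=O)C4(C(=O)Nc5ccccc5)CC4)cc3)nc2n1C1CCCC1` gives 93.9% and compound 2 `Cc1ccc(NC(=O)C2(C(=O)Nc3ccc(Nc4ncc5cc(C(=O)N(C)C)n(C6CCCC6)c5n4)cc3)CC2)cc1` gives 99.6%; the steps of a number 1.4 percentage points higher from compound 1 to compound 3 (within the scatter) and a number 4.3 percentage points lower from compound 2 to compound 3 (within the scatter) both lie within the scatter, as does a number 5.7 percentage points higher from compound 1 to compound 2 (within the scatter). Compound 4 `COc1cccc(NC(=O)C2(C(=O)Nc3ccc(Nc4ncc5cc(C(=O)N(C)C)n(C6CCCC6)c5n4)cc3)CC2)c1` differs from compound 3 by methoxy in place of methyl on an aromatic carbon. Going by the values given here, no measured step exchanges a methyl for a methoxy; the three steps that touch this ring, all within the scatter, show growth inhibition staying near the top of the range whatever small group sits there. Compound 4 is therefore expected to give 94%, between 85% and 100%, a step of a number 1.3 percentage points lower from compound 3 to compound 4 (within the scatter) expected to remain within the scatter.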

Compound 4, percent growth inhibition at one concentration: 93.5%
Beside the measured number, compound 4's estimate is 0.5 percentage points above it, and the stated range covers the measured number.
By their numbers in this assay, from the lowest: compounds 4, 1, 3 and 2 (each within the scatter of the next).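

In this assay, methoxy brings this ring a hydrogen-bond acceptor and an oxygen, yet a number 1.8 percentage points lower from compound 3 to compound 4 (within the scatter) and a number 0.4 percentage points lower from compound 1 to compound 4 (within the scatter) and a number 6.1 percentage points lower from compound 2 to compound 4 (within the scatter) all stay small. The place meta to a large group therefore tolerates methoxy as well as methyl or hydrogen, though all these numbers lie near the top of the scale at a single concentration. Nothing shown gives a measured reason for this.

From the compounds shown here alone, whether an amine, a carboxylic acid or a longer ether chain on this ring would hold the number stays open. So does whether these compounds would separate at a lower concentration.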